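This account rests on a few compounds, and the source may have more. Where it says the series, first, only, none or still open, it means among the compounds named here.

Compounds measured in an in vitro assay on Sf9 cells for inhibition of Rho-associated protein kinase 2 (Homo sapiens), read by TR-FRET, with a stated time of 25 min (a higher number here means a weaker inhibitor, a lower number a stronger inhibitor), so far:
Compound 1 `NC(c1ccc(Cl)cc1)c1nc2ccc(-c3cn[nH]c3)cc2c(=O)[nH]1` gives 10 nM in this assay.
Compound 2 `C[N+]1(C)C[C@@H](c2ccccc2)[C@H](c2nc3ccc(-c4cn[nH]c4)cc3c(=O)[nH]2)C1` gives 4 nM in this assay.
Compound 3 `NCc1cccc(C(=O)NC(c2ccc(Cl)cc2)c2nc3ccc(-c4cn[nH]c4)cc3c(=O)[nH]2)c1` gives 20 nM in this assay.

Compound 3 stands at the highest of the three numbers. Its nearest neighbour is compound 1, whose number is lower by a margin inside the scatter, so the two cannot be separated; compound 2 lies furthest away, with a lower number beyond the scatter. Going by the values given here, no step is drawn between compound 2 and compound 3, so only the two values themselves can be set side by side.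

Compound 4 `NCCC(=O)NC(c1ccc(Cl)cc1)c1nc2ccc(-c3cn[nH]c3)cc2c(=O)[nH]1` is the next member and has not yet been measured. It differs from compound 3 in one place: 2-aminoethyl in place of 3-(aminomethyl)phenyl on a carbonyl carbon. Among the compounds with values here, the one measured step that bears on this position is a 2.0-fold higher number from compound 1 to compound 3 (0.30 log units; within the scatter), which shows that attaching the whole (3-(aminomethyl)phenyl)carbonyl to the amine nitrogen of compound 1 moved the number only within the scatter. Trading that group for the shorter 2-aminoethyl on the same carbonyl carbon is therefore expected to leave the number close to where compound 3 sits, with no step beyond the scatter; the expected step is no change at the digits printed from compound 3 to compound 4 (within the scatter). For compound 4 the estimate in this assay is 20 nM, expected to fall between 7 nM and 60 nM.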

Compound 4, half-maximal inhibitory concentration: 6 nM
Beside the measured number, compound 4's estimate is 3.3-fold (0.52 log units) above it; the measured number lies below the stated range.
By their numbers in this assay, from the lowest: compounds 2, 4, 1 and 3 (each within the scatter of the next, the first and the last beyond it).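

In this assay, going by these compounds alone, the group on the carbonyl carbon matters: 2-aminoethyl in place of 3-(aminomethyl)phenyl gives the first step at this position to lie beyond the scatter (a 3.3-fold lower number from compound 3 to compound 4 (0.52 log units; beyond the scatter)). Set against the free amine of compound 1, neither amide can be separated from it, as the steps (a 2.0-fold higher number from compound 1 to compound 3 (0.30 log units; within the scatter)) and (a 1.7-fold lower number from compound 1 to compound 4 (0.22 log units; within the scatter)) both lie within the scatter, so the series so far shows a difference between the two amides but no clear gain or loss from acylating the amine nitrogen. No measurement at hand offers an explanation for the difference between the two amides, which therefore stands as an observation only.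

The change from 3-(aminomethyl)phenyl to 2-aminoethyl removes the aromatic ring and shortens the group in a single move, so the compounds shown cannot say which of these goes with the step; a benzyl group, or a longer chain such as 3-aminopropyl, on the same carbonyl carbon would begin to separate the two. Going by these compounds, whether the terminal amine contributes at all also remains open, and a plain ethyl group or a hydroxyethyl group in its place would address that.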